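A tert-Butyl Amide in a Weak Phospholipase Inhibitor Series

This account rests on a few compounds, and the source may have more. Where it says the series, first, only, none or still open, it means among the compounds named here.

Compound 1 `CCOC(=O)c1cccc(-c2ccc(N(C)C)cc2)c1` gives 40000 nM in an assay on COS-7 cells for inhibition of patatin-like phospholipase domain-containing protein 2 (Mus musculus); a higher number here means a weaker inhibitor, a lower number a stronger inhibitor. Compound 2 `CC(C)OC(=O)Nc1cccc(-c2ccc(N(C)C)cc2)c1` gives 82000 nM in the same assay, a change of a 2.1-fold higher number from compound 1 to compound 2 (0.31 log units; beyond the scatter). Compound 3 `CN(C)c1ccc(-c2cccc(NC(=O)N3CCOCC3)c2)cc1` reaches only a limit of the assay, > 200000 nM, so no number is known for it; the step of an at least 2.4-fold higher number from compound 2 to compound 3 (0.38 log units; beyond the scatter) is therefore a lower bound. Of the three values shown, compound 3 is the one that sits at the limit of > 200000 nM in this assay, at which 1 of the 3 values shown sits.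

Compound 4 `CN(C)c1ccc(-c2cccc(NC(=O)C(C)(C)C)c2)cc1` differs from compound 3 by tert-butyl in place of morpholin-4-yl on a carbonyl carbon. The two measured steps that bear on it, a 2.1-fold higher number from compound 1 to compound 2 (0.31 log units; beyond the scatter) and an at least 2.4-fold higher number from compound 2 to compound 3 (0.38 log units; beyond the scatter), both alter the group attached to the carbonyl carbon and both moved the number by modest amounts, and both upward. Another change at the same carbonyl carbon is therefore expected to stay within a modest range, in either direction, starting from a limit.

Compound 4 is estimated at 200000 nM, with a range from 60000 nM to 500000 nM. The expected step is a number no higher from compound 3 to compound 4 (the limit leaves the size open), with a considerable chance that the assay again reports only a limit for compound 4.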

Compound 4, half-maximal inhibitory concentration: > 200000 nM
Compound 4: a limit, no number; the forecaster's own chance of this, stated with the estimate: 55%; the middle value lies on the limit itself.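

In this assay compound 4 gives > 200000 nM, which is a limit of the assay and not a number. Compound 3 and compound 4 therefore cannot be ranked against each other, and the step between them cannot be read: the limit of > 200000 nM in this assay, at which 2 of the 4 values shown sit. For the compounds shown here, the new information is that morpholin-4-yl is not the only group on this carbonyl carbon that reaches the limit, since tert-butyl, which has no ring and no hydrogen-bond acceptor, also does so, with an at least 2.4-fold higher number from compound 2 to compound 4 (0.38 log units; beyond the scatter) and an at least 5.0-fold higher number from compound 1 to compound 4 (0.69 log units; beyond the scatter).

The compounds shown leave open whether any group on this carbonyl carbon can bring the number down from the level of the ethyl ester, compound 1. A methyl group, a longer chain ending in an amine or a carboxylic acid could test this.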